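The source may report more compounds than this note shows. Statements on the series, on what has been measured and on what is new or still open speak of the compounds shown alone.

Compound 1 `O=C(CSc1nnc(-c2ccncc2)o1)N/N=C/c1ccc([N+](=O)[O-])cc1`: in a functional assay on MCF7 cells (Homo sapiens) for cytotoxicity, read by MTT assay, with a stated time of 48 h (a higher number here means a weaker inhibitor, a lower number a stronger inhibitor), compound 1 gives 31800 nM.
Compound 2 `COc1ccc(/C=N/NC(=O)CSc2nnc(-c3ccncc3)o2)cc1`: compound 2 gives 17600 nM.
Compound 3 `O=C(CSc1nnc(-c2ccncc2)o1)N/N=C/c1cc(Br)cc(Br)c1O`: compound 3 gives 9010 nM.

Compound 3 stands at the low end of these three numbers; only its gap to compound 1 lies beyond the scatter, while its gap to compound 2 lies within it. Compound 4 `O=C(CSc1nnc(-c2ccncc2)o1)N/N=C/c1ccc(O)c(O)c1` differs from compound 3 in one place: 3,4-dihydroxyphenyl in place of 3,5-dibromo-2-hydroxyphenyl on a carbon with a double bond to nitrogen. Within the data shown here, no measured step swaps these two groups directly. The nearest guides are a 3.5-fold lower number from compound 1 to compound 3 (0.55 log units; beyond the scatter) and a 2.0-fold lower number from compound 2 to compound 3 (0.29 log units; within the scatter), which show that exchanging the ring at this position shifts the number by no more than a modest amount. A shift of similar size, without a clear direction, is expected here, so compound 4 is expected to give 15000 nM, between 4000 nM and 50000 nM, corresponding to a 1.7-fold higher number from compound 3 to compound 4 (0.22 log units; within the scatter).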

Compound 4, half-maximal inhibitory concentration: 910 nM
Compound 4: the middle estimate sits 16-fold (1.22 log units) above what was measured; measured number outside the range, below it.
By their numbers in this assay, from the lowest: compound 4; then compounds 3, 2 and 1 (each within the scatter of the next, the first and the last beyond it).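

In this assay, among these compounds, the ring on the carbon with a double bond to nitrogen matters far more than the earlier compounds suggested: 3,4-dihydroxyphenyl gives a 9.9-fold lower number from compound 3 to compound 4 (1.00 log units; beyond the scatter), a 19-fold lower number from compound 2 to compound 4 (1.29 log units; beyond the scatter) and a 35-fold lower number from compound 1 to compound 4 (1.54 log units; beyond the scatter). The earlier rings, 4-nitrophenyl, 4-methoxyphenyl and 3,5-dibromo-2-hydroxyphenyl, lay much closer together, so this position allows a far larger change than they showed. Nothing available explains why this ring stands apart. Still open, as far as these compounds go, is whether the lower number needs both hydroxy groups, and how a ring carrying an amine or a carboxylic acid instead would compare.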